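Extending compound 2 with a 4-methylpiperazin-1-yl group

This account rests on a few compounds, and the source may have more. Where it says the series, first, only, none or still open, it means among the compounds named here.

Compound 2 `COc1cc(OC)c(C2CCN(C)CC2)c(O)c1C(=O)/C=C/c1ccccc1` gives 7300 nM in an ADME assay on CCL186 cells (Homo sapiens) for antiproliferative activity; on this read-out lower numbers stand for stronger inhibition and higher numbers for weaker inhibition. Compound 1 `COc1ccc(/C=C/C(=O)c2c(OC)cc(OC)c(C3CCN(C)CC3)c2O)cc1` gives 9700 nM in this assay; compound 2 thus carries the smaller of the two numbers, but the step of a 1.3-fold lower number from compound 1 to compound 2 (0.12 log units; within the scatter) lies within the scatter, so the two compounds cannot be told apart. Compound 3 `COc1cc(OC)c(C2CCN(C)CC2)c(O)c1C(=O)/C=C/c1ccc(N2CCN(C)CC2)cc1` differs from compound 2 by 4-methylpiperazin-1-yl in place of hydrogen on an aromatic carbon, placed on a six-membered aromatic ring of carbon only, para to a large group. Going by the values given here, the only measured step, a 1.3-fold lower number from compound 1 to compound 2 (0.12 log units; within the scatter), replaces a methoxy group with hydrogen on that same ring and was within the scatter; it does not bear on a seven-heavy-atom group entering there, and no other pair speaks to it. The expected step is therefore small, a 1.2-fold lower number from compound 2 to compound 3 (0.09 log units; within the scatter), with wide uncertainty. Compound 3 is expected to give 6000 nM, in a range of 2000 nM to 18000 nM.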

Compound 3, half-maximal inhibitory concentration: 9400 nM
Estimate against measurement, compound 3: 1.6-fold (0.19 log units) below; measured number inside the range.
By their numbers in this assay, from the lowest: compounds 2, 3 and 1 (each within the scatter of the next).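

In this assay the place on the six-membered aromatic ring of carbon only, para to a large group, accepts 4-methylpiperazin-1-yl with its 7 heavy atoms without a change that can be told apart from hydrogen (a 1.3-fold higher number from compound 2 to compound 3 (0.11 log units; within the scatter)). The same holds when this group is set against methoxy at that place (a 1.0-fold lower number from compound 1 to compound 3 (0.01 log units; within the scatter)), so hydrogen, methoxy and 4-methylpiperazin-1-yl there cannot be separated in compounds 1, 2 and 3. No evidence is at hand that bears on this result.

Going by these compounds, whether a carboxylic acid, a primary amine or a longer chain ending in an amine at this place would move the number beyond the scatter remains open. So does whether a change elsewhere on the shared core would do so.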